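Swapping an aromatic ring for a saturated one in compound 1

The source may hold more compounds than are shown below. What is called first, only, known or untested is meant among the compounds shown, and "the series" means these compounds.

Measured compounds:
- compound 1 `Cc1cccc([C@@H](O)C(=O)N2N=CC[C@H]2C(=O)NCc2cc(Cl)ccc2-n2cnnn2)c1`: < 12 mL.min-1.g-1
- compound 2 `O=C(NCc1cc(Cl)ccc1-n1cnnn1)[C@@H]1C[C@H]2C[C@H]2N1C(=O)[C@H](O)CC1CC1`: 25 mL.min-1.g-1
- compound 3 `CC(C)(C)C[C@@H](O)C(=O)N1C[C@@H]2C[C@@H]2[C@H]1C(=O)NCc1cc(Cl)ccc1-n1cnnn1`: 20 mL.min-1.g-1

The three compounds share a core and were tested in an ADME assay on liver for metabolic stability, with Liver microsome (Homo sapiens) as the target, read by LC-MS, using microsomes; a higher number here means faster removal of the compound, a lower number slower removal. Compound 1 gives < 12 mL.min-1.g-1, which is a limit of the assay rather than a number. Compound 2 gives 25 mL.min-1.g-1 and compound 3 gives 20 mL.min-1.g-1 in this assay; these two values show no difference beyond the usual scatter. Compound 1 therefore stands at the low end of what is shown, and the one fact known about it is the limit of < 12 mL.min-1.g-1 in this assay, at which 1 of the 3 values shown sits.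

The unmeasured compound 4 `O=C(NCc1cc(Cl)ccc1-n1cnnn1)[C@@H]1CC=NN1C(=O)[C@H](O)C1CCCCC1` differs from compound 1 in one place: cyclohexyl in place of 3-methylphenyl on a saturated chain carbon bound to a carbonyl carbon and an oxygen on a saturated carbon. Among the measured compounds shown here, since no pair of measured compounds differs in one place, no measured step shows what such a change does.

Compound 2 and compound 3 carry saturated groups at the same kind of place, and their values lie above the limit of compound 1, so compound 4 is expected to show a modest rise, with a step of an at least 2.0-fold higher number from compound 1 to compound 4 (0.31 log units; beyond the scatter). Compound 4 is estimated at 25 mL.min-1.g-1, within a range from 10 mL.min-1.g-1 to 60 mL.min-1.g-1 in this assay.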

Compound 4, intrinsic clearance in microsomes: 63 mL.min-1.g-1
Estimate against measurement, compound 4: 2.5-fold (0.40 log units) below; measured number above the stated range.
By their numbers in this assay, from the lowest: compounds 3 and 2 (each within the scatter of the next); then compound 4. At a limit, below all of these: compound 1.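

In this assay, putting cyclohexyl in place of 3-methylphenyl on this saturated chain carbon, with the rest of the molecule unchanged, gives an at least 5.2-fold higher number from compound 1 to compound 4 (0.72 log units; beyond the scatter). This is the first comparison shown in which only this group changes, so the rise can be tied to this one swap, which compound 2 and compound 3 could not show, as each differs from compound 1 in more than one place. The figure for compound 1 is a limit of the assay and not a number: the limit of < 12 mL.min-1.g-1 in this assay, at which 1 of the 4 values shown sits.

The compounds shown leave open where a plain phenyl, a tetrahydropyranyl or a piperidinyl group at this place would fall relative to compound 1 and compound 4. This single pair also leaves open whether the same swap gives a similar rise on a different core.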